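The source may report more compounds than this note shows. Statements on the series, on what has been measured and on what is new or still open speak of the compounds shown alone.

In a functional assay on HCT-116 cells (Homo sapiens) for inhibition, read by MTT assay, with a stated time of 2 days, tested at 10 uM (on this read-out higher numbers stand for more inhibition at the one concentration tested (going by the name of the read-out) and lower numbers for less inhibition), compound 3 `COc1ccc(-c2cn(-c3ccc(O)c(C(=O)OCCCc4ccccc4)c3)nn2)cc1` gives 12%, the lowest of the three measured numbers. Compound 1 `COc1cc(OC)cc(-c2cn(-c3ccc(O)c(C(=O)OCCCc4ccccc4)c3)nn2)c1` gives 19%, and the step of a number 7 percentage points lower from compound 1 to compound 3 (within the scatter) lies within the scatter. Compound 2 `O=C(OCCCc1ccccc1)c1cc(-n2cc(-c3cc(O)ccc3O)nn2)ccc1O` gives 39%, and the step of a number 27 percentage points lower from compound 2 to compound 3 (beyond the scatter) is beyond it. Compound 4 `COc1ccc(OC)c(-c2cn(-c3ccc(O)c(C(=O)OCCCc4ccccc4)c3)nn2)c1` differs from compound 3 in one place: 2,5-dimethoxyphenyl in place of 4-methoxyphenyl on an aromatic carbon. The step from compound 1 to compound 3, which also swaps one methoxy pattern for another, was within the scatter; only the dihydroxyphenyl of compound 2 stood out. A second methoxy group is therefore expected to change the read-out little, and the step of a number 8 percentage points higher from compound 3 to compound 4 (within the scatter) is estimated to stay within the scatter. For compound 4 the expected value is 20%, likely between 8% and 36%.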

Compound 4, a percentage reported as inhibition, at one concentration (the size of the read-out at that concentration, not a potency): 13%
Beside the measured number, compound 4's estimate is 7 percentage points above it; measured number inside the range.
By their numbers in this assay, from the lowest: compounds 3, 4 and 1 (each within the scatter of the next); then compound 2.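

Swapping 4-methoxyphenyl for 2,5-dimethoxyphenyl gives a number 1 percentage points higher from compound 3 to compound 4 (within the scatter) in this assay, and swapping 3,5-dimethoxyphenyl for it gives a number 6 percentage points lower from compound 1 to compound 4 (within the scatter), so neither the methoxy count nor the pattern separates these compounds. Replacing 2,5-dihydroxyphenyl with 2,5-dimethoxyphenyl, which keeps the pattern unchanged, gives a number 26 percentage points lower from compound 2 to compound 4 (beyond the scatter), which ties the higher number of compound 2 to its hydroxy groups rather than their positions. No measured evidence explains this difference. From the compounds shown here alone, how a single hydroxy group, an amine or a carboxylic acid on this ring would read remains open.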